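Swapping the Linker Atom: From Compound 3 to Compound 4

The compounds below may be only part of what the source reports. "The series", "measured", "known", "first", "only" and "open" are said of these compounds alone.

Measured compounds in an assay on isolated protein for inhibition of Retinaldehyde dehydrogenase 3 (Homo sapiens); a higher number here means a weaker inhibitor, a lower number a stronger inhibitor:
- compound 1, `Cn1ncc2c(=O)n(-c3ccccc3)c(COc3cccc(F)c3)nc21`: 780 nM
- compound 2, `CC(C)C(Sc1nc2c(cnn2C)c(=O)n1-c1ccccc1)c1ccccc1`: 130 nM
- compound 3, `Cn1ncc2c(=O)n(-c3ccccc3)c(CCc3cccc(F)c3)nc21`: 2500 nM

Among the three measured compounds, compound 3 gives the highest number in this assay: its nearest neighbour is compound 1, with a step of a 3.2-fold higher number from compound 1 to compound 3 (0.51 log units; beyond the scatter), and the furthest is compound 2, whose value lies well below.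

Compound 4, `Cn1ncc2c(=O)n(-c3ccccc3)c(CNc3cccc(F)c3)nc21`, has not yet been measured. It differs from compound 3 in one place: (3-fluorophenyl)amino in place of 3-fluorobenzyl on a saturated chain carbon bound to an aromatic carbon. Going by the values given here, the one measured step that bears on this change is the one from compound 1 to compound 3, which also alters the atom linking the 3-fluorophenyl ring to the chain carbon, and which was a 3.2-fold higher number from compound 1 to compound 3 (0.51 log units; beyond the scatter). Compound 2 shares the core but changes more than this one spot, so its value is not read as a step here.

Since the change in compound 4 puts a donor-bearing nitrogen where compound 1 carried an oxygen and compound 3 a carbon, the number for compound 4 is expected to land between those two, giving an expected step of a 1.9-fold lower number from compound 3 to compound 4 (0.28 log units; within the scatter) in this assay. Compound 4 is therefore estimated at 1300 nM, with a range from 450 nM to 3800 nM.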

Compound 4, half-maximal inhibitory concentration: 1050 nM
Estimate against measurement, compound 4: 1.2-fold (0.09 log units) above, within the range that was stated.
By their numbers in this assay, from the lowest: compound 2; then compounds 1 and 4 (each within the scatter of the next); then compound 3.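

With a third linking atom now tested at this place on a saturated chain carbon bound to an aromatic carbon, the earlier single step can be read more fully in this assay: (3-fluorophenyl)amino in place of 3-fluorobenzyl gives a 2.4-fold lower number from compound 3 to compound 4 (0.38 log units; beyond the scatter) and so recovers inhibition lost with the all-carbon link. The amino and 3-fluorophenoxy groups cannot be told apart, with a 1.3-fold higher number from compound 1 to compound 4 (0.13 log units; within the scatter) and thus no ordering of the two, so among these three compounds only the 3-fluorobenzyl group of compound 3 stands apart. Nothing measured here accounts for this difference.

The compounds shown leave open whether the hydrogen on the linking nitrogen of compound 4 matters, which an N-methylamine at the same place would test, since the hydrogen-bond donor entering with the amino group has no bearing on compound 1 and its oxygen link. They also leave open how a thioether or amide link would compare on the same core, and whether the same pattern would hold with a longer chain.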